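Smaller Substituent on the Aminopyrimidine Nitrogen: Compound 4

The source may report more compounds than this note shows. Statements on the series, on what has been measured and on what is new or still open speak of the compounds shown alone.

Three compounds share one core and differ only in the group on a nitrogen on an aromatic ring. Compound 1 `C=CC(=O)Nc1cc(Nc2ncc(Cl)c(Nc3ccccc3S(=O)(=O)C(C)C)n2)c(OC)cc1N1CCN(C)CC1` gives 43 nM in a functional assay on NCI-H1975 cells (Homo sapiens) for inhibition, read by CellTiter-Glo, with a stated time of 72 h; on this read-out lower numbers stand for stronger inhibition of growth and higher numbers for weaker inhibition of growth. Compound 2 `C=CC(=O)Nc1cc(Nc2ncc(Cl)c(Nc3cccc(C(F)(F)F)c3)n2)c(OC)cc1N1CCN(C)CC1` gives 260 nM in this assay, and compound 3 `C=CC(=O)Nc1cc(Nc2ncc(Cl)c(NCc3cccs3)n2)c(OC)cc1N1CCN(C)CC1` gives 220 nM. Compound 3 thus stands second highest of the three numbers: its nearest neighbour is compound 2, with a 1.2-fold lower number from compound 2 to compound 3 (0.07 log units; within the scatter), and its furthest is compound 1, with a 5.1-fold higher number from compound 1 to compound 3 (0.71 log units; beyond the scatter).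

Compound 4 `C=CC(=O)Nc1cc(Nc2ncc(Cl)c(NC3CC3)n2)c(OC)cc1N1CCN(C)CC1` differs from compound 3 in one place: cyclopropyl in place of (thiophen-2-yl)methyl on a nitrogen on an aromatic ring. For the measured compounds named here, no measured step covers this exact exchange. Going by the values given here, the steps that bear on it indirectly, a 6.0-fold higher number from compound 1 to compound 2 (0.78 log units; beyond the scatter) and a 5.1-fold higher number from compound 1 to compound 3 (0.71 log units; beyond the scatter), both show that the group on this nitrogen can move the number by a modest amount, whereas the exchange between two quite different groups, a 1.2-fold lower number from compound 2 to compound 3 (0.07 log units; within the scatter), stayed within the scatter. Cyclopropyl is the smallest group tried here, and nothing in the three measurements points to a gain from a smaller group. He therefore expects compound 4 to give about 350 nM in this assay, within a range of 120 nM to 1100 nM. That amounts to an expected step of a 1.6-fold higher number from compound 3 to compound 4 (0.20 log units; within the scatter), a small loss or none beyond the scatter.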

Compound 4, concentration for 50% growth inhibition: > 10000 nM
Compound 4 was reported as a limit; the forecaster's own chance of this, stated with the estimate: 5%; middle value at least 28-fold (1.45 log units) away from the limit.
By their numbers in this assay, from the lowest: compound 1; then compounds 3 and 2 (each within the scatter of the next). At a limit, above all of these: compound 4.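

Compound 4 is reported only as a limit of the assay and not as a number: the limit of > 10000 nM in this assay, at which 1 of the 4 values shown sits. The earlier exchanges on this nitrogen had moved the number modestly or not beyond the scatter, whereas this one gives large steps: an at least 45-fold higher number from compound 3 to compound 4 (1.65 log units; beyond the scatter), an at least 38-fold higher number from compound 2 to compound 4 (1.58 log units; beyond the scatter) and an at least 230-fold higher number from compound 1 to compound 4 (2.36 log units; beyond the scatter). For the compounds shown here, the position therefore tolerates less than the first three compounds suggested: (thiophen-2-yl)methyl and 3-(trifluoromethyl)phenyl, though quite different, stay within the scatter of each other, while cyclopropyl, the only group of the four without an aromatic ring, stands apart from all of them.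

The compounds shown leave open whether this drop goes with the missing aromatic ring or with the fewer heavy atoms, as cyclopropyl differs from the other groups in both respects. A cyclohexyl group or a longer carbon chain such as n-hexyl on this nitrogen would tell the two apart, and a plain phenyl would show how much of the number of compound 1 depends on its isopropylsulfonyl group.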